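Replacing 3-chlorophenyl with 1,2-thiazol-4-yl: tolerated concentration outlook

The compounds below may be only part of what the source reports. "The series", "measured", "known", "first", "only" and "open" are said of these compounds alone.

Compound 1 `COc1nc(C2CCOCC2)ccc1[C@@H](c1ccccc1)[C@@](O)(CCN(C)C)c1cccc2ccccc12`: in a toxicity assay on Vero cells (Chlorocebus sabaeus) for cytotoxicity (a lower number here means that less compound is tolerated, a higher number that more compound is tolerated), compound 1 gives > 50 ug/mL, which is a limit of the assay rather than a number.
Compound 2 `COc1nc(-c2cccc(Cl)c2)ccc1[C@@H](c1ccccc1)[C@@](O)(CCN(C)C)c1cccc2ccccc12`: compound 2 gives > 50 ug/mL, again a limit.
Compound 3 `COc1ncc(-c2ccccc2)cc1[C@@H](c1ccccc1)[C@@](O)(CCN(C)C)c1cccc2ccccc12`: compound 3 gives > 50 ug/mL, also a limit.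

Compound 2 therefore stands where every value shown stands, at the limit of > 50 ug/mL in this assay, at which 3 of the 3 values shown sit. Going by the values given here, the single measured step, a step that the two limits leave unreadable from compound 1 to compound 2, cannot be read because both of its ends sit at the limit of > 50 ug/mL in this assay, at which 3 of the 3 values shown sit.

Compound 4 `COc1nc(-c2cnsc2)ccc1[C@@H](c1ccccc1)[C@@](O)(CCN(C)C)c1cccc2ccccc12` differs from compound 2 in one place: 1,2-thiazol-4-yl in place of 3-chlorophenyl on an aromatic carbon. Among the compounds with values here, no measured step gives a readable size for any change at this position, so no step beyond the scatter is expected; the estimate implies a step that the limit leaves unreadable from compound 2 to compound 4. Compound 4 is expected to give about 60 ug/mL, within 30 ug/mL to 120 ug/mL, most likely reported again only as a limit.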

Compound 4, half-maximal cytotoxic concentration: 26.3 ug/mL
The estimate for compound 4 lay 2.3-fold (0.36 log units) above the measured number; measured number below the stated range.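

Compound 4 is the first compound here to give a real number in this assay, so a group at this place, next to the ring nitrogen, can bring the read-out down from the limit: the limit of > 50 ug/mL in this assay, at which 3 of the 4 values shown sit.

Swapping in 1,2-thiazol-4-yl gives an at least 1.9-fold lower number from compound 2 to compound 4 (0.27 log units; that floor lies within the scatter), and it gives an at least 1.9-fold lower number from compound 1 to compound 4 (0.27 log units; that floor lies within the scatter). These are only floors, so neither step is shown to exceed the scatter.

From the compounds shown here alone, the true size of both steps stays open, since the values of compound 1 and compound 2 are limits. Going by these compounds, whether an amine or a carboxylic acid at this place would also give a number below the limit remains open too.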